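A few compounds are considered here, and "the series" means these few. Any claim that something is new, unique, unknown or untested is made for them only; others in the source may bear on it.

Three compounds from one series were tested in a functional assay on A549 cells (Homo sapiens), read by MTT assay, with a stated time of 72 h; a lower number here means a stronger inhibitor, a higher number a weaker inhibitor. For the measured compounds named here, compound 1 `COc1ncnc2c1c(-c1ccccc1)cn2[C@@H]1O[C@H](CO)[C@@H](O)[C@H]1O` is the first of them. In this assay compound 1 gives > 20000 nM, which is a limit of the assay and not a number. Compound 2 `O=c1[nH]cnc2c1c(-c1cc3ccccc3o1)cn2[C@@H]1O[C@H](CO)[C@@H](O)[C@H]1O` bears a 1-benzofuran-2-yl group on an aromatic carbon of the shared core. In this assay compound 2 gives > 20000 nM, again a limit. Compound 3 `O=c1[nH]cnc2c1c(-c1ccsc1)cn2[C@@H]1O[C@H](CO)[C@@H](O)[C@H]1O` carries thiophen-3-yl in the same place. In this assay compound 3 gives > 20000 nM, once more a limit. Compound 3 therefore stands with the other two at the edge of what the assay can report, as the limit of > 20000 nM in this assay, at which 3 of the 3 values shown sit, shows. Going by the values given here, the one step between measured compounds, a step that the two limits leave unreadable from compound 2 to compound 3, has no readable size: both of its values are limits.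

Compound 4 `O=c1[nH]cnc2c1c(-c1cccs1)cn2[C@@H]1O[C@H](CO)[C@@H](O)[C@H]1O` differs from compound 3 in one place: thiophen-2-yl in place of thiophen-3-yl on an aromatic carbon. Among the compounds with values here, no measured step bears directly on this rearrangement, and the only step available, a step that the two limits leave unreadable from compound 2 to compound 3, gives no size. No shift beyond the scatter is expected, so compound 4 is expected to remain at the limit, with an estimate of 30000 nM and a range from 15000 nM to 100000 nM. This expectation means a step that the limit leaves unreadable from compound 3 to compound 4.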

Compound 4, half-maximal inhibitory concentration: > 20000 nM
Compound 4 was reported as a limit (the forecaster's own chance of this, stated with the estimate: 85%); the middle value is on the limit's open side.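

Compound 4 gives > 20000 nM in this assay, which is a limit of the assay and not a number. Its steps from compound 2 and from compound 3 therefore cannot be read. The compounds shown leave open whether any of these groups on the shared core differs from another in strength, as all stand together at one edge: the limit of > 20000 nM in this assay, at which 4 of the 4 values shown sit.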